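This account rests on a few compounds, and the source may have more. Where it says the series, first, only, none or still open, it means among the compounds named here.

Compound 1 `ClCc1cccc(Cn2cnc3ncnc(Cl)c32)c1`: 3540 nM
Compound 2 `ClCc1cccc(Cn2cnc3c(Cl)nc(Cl)nc32)c1`: 3890 nM

In a functional assay on SNB-75 cells (Homo sapiens) for cytotoxicity, read by sulforhodamine B assay, with a stated time of 48 h (a higher number here means a weaker inhibitor of growth, a lower number a stronger inhibitor of growth), compound 1 gives 3540 nM, and compound 2 gives 3890 nM. These two numbers lie within the usual scatter of each other, so nothing separates compound 1 from compound 2 on these data. Compound 3 `ClCc1cccc(Cn2cnc3nc(Cl)nc(Cl)c32)c1` differs from compound 1 by chloro in place of hydrogen on an aromatic carbon. Within the data shown here, no measured pair shows what such a change does in this assay . Since compound 2, another chloro-bearing analog of the shared core, gives 3890 nM, compound 3 is expected to stay close, with a step of a 1.0-fold higher number from compound 1 to compound 3 (0.02 log units; within the scatter) not beyond the scatter. For compound 3 the estimate is 3700 nM, likely between 1500 nM and 9000 nM.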

Compound 3, concentration for total growth inhibition: 2290 nM
Compound 3: the middle estimate sits 1.6-fold (0.21 log units) above what was measured; the range from low to high includes it.
By their numbers in this assay, from the lowest: compounds 3, 1 and 2 (each within the scatter of the next).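

On the aromatic carbon between two ring nitrogen atoms, chloro in place of hydrogen gives a 1.5-fold lower number from compound 1 to compound 3 (0.19 log units; within the scatter) in this assay. Among these compounds, this is the first direct reading of this change, and it shows that this position can carry a chloro group without a shift that can be told from ordinary repeat variation. No separate measurement offers an explanation for this result. Going by these compounds, whether an amine, a methoxy group or a longer chain at this carbon would move the number beyond the scatter remains open.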